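The compounds below may be only part of what the source reports. "The series", "measured", "known", "first", "only" and "open" are said of these compounds alone.

Of the compounds shown here, two with a shared core have been measured in an ADME assay on CCRF-CEM cells (Homo sapiens) for cytotoxicity, read by MTT assay, with a stated time of 5 days; on this read-out lower numbers stand for higher toxicity in this test and higher numbers for lower toxicity in this test. Compound 1 `COc1cc(Cc2cnc(/N=C3\C(=O)N(CN4CCN(C)CC4)c4ccc(Cl)cc43)nc2N)cc(OC)c1OC` gives 88 ug/mL. Compound 2 `COc1cc(Cc2cnc(/N=C3\C(=O)N(CN4CCN(c5ccc(F)cc5)CC4)c4ccc(Cl)cc43)nc2N)cc(OC)c1OC` gives 71 ug/mL, and the change a 1.2-fold lower number from compound 1 to compound 2 (0.09 log units; within the scatter) shows that the two numbers sit within the usual scatter of each other. Compound 3 `COc1cc(Cc2cnc(/N=C3\C(=O)N(CN4CCN(c5ccccn5)CC4)c4ccc(Cl)cc43)nc2N)cc(OC)c1OC` carries a further change at the same place: pyridin-2-yl in place of 4-fluorophenyl on an amine nitrogen in a ring. Going by the values given here, the only comparable step, a 1.2-fold lower number from compound 1 to compound 2 (0.09 log units; within the scatter), was small, so for compound 3 no move beyond the scatter is expected in this assay. The estimated value for compound 3 is 75 ug/mL, within a range from 45 ug/mL to 130 ug/mL, corresponding to an expected step of a 1.1-fold higher number from compound 2 to compound 3 (0.02 log units; within the scatter).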

Compound 3, half-maximal cytotoxic concentration: 29.4 ug/mL
Compound 3: the middle estimate sits 2.6-fold (0.41 log units) above what was measured; measured number outside the range, below it.
By their numbers in this assay, from the lowest: compound 3; then compounds 2 and 1 (each within the scatter of the next).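

In this assay this position proves sensitive to the group on the ring nitrogen: pyridin-2-yl brings a 2.4-fold lower number from compound 2 to compound 3 (0.38 log units; beyond the scatter) and a 3.0-fold lower number from compound 1 to compound 3 (0.48 log units; beyond the scatter) and so marks higher toxicity in this test. The earlier swap of methyl for 4-fluorophenyl stayed within the scatter, so a large aromatic ring here does not by itself lower the number. No measurement at hand explains this drop. From the compounds shown here alone, whether it depends on the nitrogen atom in the new ring stays open, and so does its placement: phenyl or pyridin-4-yl on the same amine nitrogen could separate these possibilities.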